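This account rests on a few compounds, and the source may have more. Where it says the series, first, only, none or still open, it means among the compounds named here.

Working notes on the series. Compound 3 `CCCCCCCCC[C@@H](O)[C@H](C)N` gives 6600 nM in a functional assay on HBL-100 cells (Homo sapiens) for antiproliferative activity, read by sulforhodamine B assay, with a stated time of 48 h (on this read-out higher numbers stand for weaker inhibition of growth and lower numbers for stronger inhibition of growth), the second highest of the three numbers; its nearest neighbour is compound 2 `CCCCCCCCCCCCCCC[C@@H](O)[C@@H](N)C(C)C` with 4900 nM, within the scatter, and its furthest is compound 1 `CCCCCCCCCCCCCCC[C@@H](O)[C@@H](N)[C@@H](C)O` with 21000 nM, beyond the scatter. Within the data shown here, the one measured step, a 4.3-fold lower number from compound 1 to compound 2 (0.63 log units; beyond the scatter), concerns the carbon bound to the amine nitrogen and says nothing about the chain. Compound 4 `CCCCCCCCCCCCCCC[C@@H](O)[C@H](C)N` differs from compound 3 by hexyl in place of hydrogen on a saturated chain carbon, ten or more bonds along the chain from an oxygen on a saturated carbon. Among the measured compounds shown here, no measured step bears on this change, so the expectation rests only on compound 2 carrying a chain of the same length as compound 4 and standing near compound 3. Compound 4 is therefore expected to show a 1.7-fold lower number from compound 3 to compound 4 (0.22 log units; within the scatter), landing at an estimated 4000 nM with a range of 1500 nM to 12000 nM.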

Compound 4, concentration for 50% growth inhibition: 2300 nM
The estimate for compound 4 lay 1.7-fold (0.24 log units) above the measured number; the measured number falls inside the stated range.
By their numbers in this assay, from the lowest: compound 4; then compounds 2 and 3 (each within the scatter of the next); then compound 1.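

In this assay, among these compounds, hexyl in place of hydrogen on a saturated chain carbon gives a 2.9-fold lower number from compound 3 to compound 4 (0.46 log units; beyond the scatter), the first measured reading on this chain change. On the saturated chain carbon bound to an amine nitrogen, methyl in place of isopropyl gives a 2.1-fold lower number from compound 2 to compound 4 (0.33 log units; beyond the scatter) and methyl in place of 1-hydroxyethyl gives a 9.1-fold lower number from compound 1 to compound 4 (0.96 log units; beyond the scatter), so methyl carries the lowest number of the three groups shown there. No measurement shown accounts for these steps. From the compounds shown here alone, a longer chain than that of compound 4 remains open, as does ethyl on the carbon bound to the amine nitrogen.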